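The source may hold more compounds than are shown below. What is called first, only, known or untested is meant among the compounds shown, and "the series" means these compounds.

Going by the values given here, compound 2, `CC(C)C(Nc1nccs1)c1ccc(-c2ccc3cccc(F)c3c2)[nH]c1=O`, has the lowest number of the two measured so far. In a functional assay on CHO cells for antagonist activity at prostaglandin E2 receptor EP3 subtype (Homo sapiens), read by cAMP accumulation (a higher number here means a weaker inhibitor, a lower number a stronger inhibitor), compound 2 gives 10 nM, while compound 1, `CC(C)C(c1ccc(-c2ccc3cccc(F)c3c2)[nH]c1=O)N1CCCCS1(=O)=O`, gives 122 nM; the step is a 12-fold lower number from compound 1 to compound 2 (1.09 log units; beyond the scatter). Compound 3, `CC(C)C(c1cnc(N)s1)c1ccc(-c2ccc3cccc(F)c3c2)[nH]c1=O`, keeps the same atoms, joined differently: 2-amino-1,3-thiazol-5-yl in place of (1,3-thiazol-2-yl)amino on a saturated chain carbon bound to an aromatic carbon and a saturated chain carbon. Among the compounds with values here, no measured step swaps one way of attaching the same ring for another; the single step only shows that this side position tolerates a large change. A small step in either direction, or none beyond the scatter, is expected, a 2.5-fold higher number from compound 2 to compound 3 (0.40 log units; beyond the scatter). Compound 3 is estimated at 25 nM, between 8 nM and 80 nM.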

Compound 3, half-maximal inhibitory concentration: 39 nM
Estimate against measurement, compound 3: 1.6-fold (0.19 log units) below; measured number inside the range.
By their numbers in this assay, from the lowest: compound 2; then compound 3; then compound 1.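

Moving the same ring, from (1,3-thiazol-2-yl)amino to 2-amino-1,3-thiazol-5-yl, gives a 3.9-fold higher number from compound 2 to compound 3 (0.59 log units; beyond the scatter), so how the ring is joined at this position matters, though less than replacing the group outright. The 2-amino-1,3-thiazol-5-yl group still does better than the six-membered non-aromatic ring it replaces, with a 3.1-fold lower number from compound 1 to compound 3 (0.50 log units; beyond the scatter), so the thiazole's advantage survives the move. Nothing measured here explains these differences. Still open, on these data alone, is whether an oxazole or a pyridine could take the thiazole's place, and what a methyl group on the free amine would do.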